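Bromo in place of vinyl on compound 2

The source may report more compounds than this note shows. Statements on the series, on what has been measured and on what is new or still open speak of the compounds shown alone.

Among the measured compounds shown here, in a functional assay on NCI-H522 cells (Homo sapiens) for cytotoxicity, with a stated time of 3 days (a higher number here means a weaker inhibitor, a lower number a stronger inhibitor), compound 1 `C=Cc1nc2ccccc2[se]1` gives 12200 nM and compound 2 `C=Cc1nc2ccccc2n1C` gives 2340 nM while compound 3 `C#Cc1nc(/C=C/C(=O)Nc2ccc(Cl)cc2)cs1` gives 370 nM as the lowest number so far. Compound 2 therefore holds the middle place, with a lower number than compound 1 and a higher number than compound 3, and both gaps lie beyond the scatter.

Compound 4 `Cn1c(Br)nc2ccccc21` keeps the core of compound 2 and carries bromo in place of vinyl on an aromatic carbon. For the measured compounds named here, no measured pair tests this change, so its size and direction remain a judgement. A higher number in this assay is expected, which would mean a weaker inhibitor. The expected move (a 3.8-fold higher number from compound 2 to compound 4 (0.59 log units; beyond the scatter)) is estimated to lie beyond the scatter, though with wide uncertainty. The estimated value for compound 4 is 9000 nM (expected range 2500 nM to 35000 nM).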

Compound 4, half-maximal inhibitory concentration: > 40000 nM
Compound 4: only a limit was reported; the forecaster's own chance of this, stated with the estimate: 25%; at least 4.4-fold (0.64 log units) between middle value and limit.
By their numbers in this assay, from the lowest: compound 3; then compound 2; then compound 1. At a limit, above all of these: compound 4.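

In this assay compound 4 gives > 40000 nM, which is a limit of the assay and not a number. This gives the series its first step with one change in one place: bromo in place of vinyl on an aromatic carbon, between two ring nitrogen atoms, yields an at least 17-fold higher number from compound 2 to compound 4 (1.23 log units; beyond the scatter), so the cytotoxicity of compound 2 does not survive this exchange at this position. The true size of the step remains unknown, and the printed size is only a bound set by the assay: the limit of > 40000 nM in this assay, at which 1 of the 4 values shown sits.

Going by these compounds, whether the vinyl group itself is required or whether bromo is specifically poor here remains open. An ethyl group, an amine or a longer alkenyl chain at this position would separate these readings, and the compounds shown do not tell whether the same exchange behaves alike on another core.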